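This account rests on a few compounds, and the source may have more. Where it says the series, first, only, none or still open, it means among the compounds named here.

Working notes on a small set of aminothiazoles examined in a physicochemical assay for solubility, in phosphate buffer, with a stated time of 2 h, at pH 7.4; a higher number here means a more soluble compound, a lower number a less soluble compound.

For the measured compounds named here, compound 1 `CCOc1ccc(-c2csc(Nc3ccc(Cl)cn3)n2)nc1` is the first parent. In this assay compound 1 gives < 10000 nM, which is a limit of the assay and not a number. Compound 2 `CCOc1ccc(-c2nc(Nc3ccc(Cl)cn3)sc2Cl)nc1` carries the change (chloro in place of hydrogen on an aromatic carbon). In this assay compound 2 gives < 10000 nM, again a limit. The step that the two limits leave unreadable from compound 1 to compound 2 cannot be sized because of the limit of < 10000 nM in this assay, at which 3 of the 3 values shown sit. Compound 3 `Clc1ccc(Nc2nc(-c3cnccn3)cs2)nc1` has a different core; the difference between the core of compound 1 and the core of compound 3 is not broken down here. In this assay compound 3 gives < 10000 nM, also a limit.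

Compound 4 `Clc1ccc(Nc2nc(-c3cnccn3)c(Cl)s2)nc1` is not yet measured and carries the same kind of change, (chloro in place of hydrogen on an aromatic carbon). The surroundings differ: in compound 4 the chloro sits next to the ring atom that bears a pyrazin-2-yl group, in compound 2 next to the ring atom that bears a group of 9 heavy atoms. Since the measured step gives no size, the expected step that the limit leaves unreadable from compound 3 to compound 4 rests only on the limit of compound 3. Compound 4 is expected at 4000 nM, most likely again reported as a limit, within 500 nM to 15000 nM.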

Compound 4, solubility: < 10000 nM
Compound 4 was reported as a limit; the forecaster's own chance of this, stated with the estimate: 85%; the middle value lies beyond the limit too.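

Compound 3 and compound 4 both stand at a limit in this assay, so no step between them can be read, and the same holds for the earlier pair: the limit of < 10000 nM in this assay, at which 4 of the 4 values shown sit.

The compounds shown leave open the size and direction of the step for chloro in place of hydrogen on an aromatic carbon, and how the core of compound 1 and the core of compound 3 compare.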